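Swapping a Long Chain for a Ring on the Amide

The compounds below may be only part of what the source reports. "The series", "measured", "known", "first", "only" and "open" are said of these compounds alone.

Three amides sharing one core have been measured in an assay on cell membranes for binding affinity to 2-oxoglutarate receptor 1 (Rattus norvegicus), read by radioligand binding; on this read-out higher numbers stand for weaker inhibition and lower numbers for stronger inhibition. Compound 1 `CCCCNC(=O)[C@H]1OC(n2cnc3c(N)ncnc32)[C@H](O)[C@@H]1O` gives 17 nM. Compound 2 `CCCCCCCCNC(=O)[C@H]1OC(n2cnc3c(N)ncnc32)[C@H](O)[C@@H]1O` gives 21 nM, and compound 3 `NCCCCCCCCNC(=O)[C@H]1OC(n2cnc3c(N)ncnc32)[C@H](O)[C@@H]1O` gives 29 nM. Compound 3 holds the highest of the three numbers, but the gaps to the others are small: a 1.7-fold higher number from compound 1 to compound 3 (0.23 log units; within the scatter) and a 1.4-fold higher number from compound 2 to compound 3 (0.14 log units; within the scatter), both within the scatter, so on these values the three compounds cannot be told apart.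

Compound 4 `Nc1ncnc2c1ncn2C1O[C@H](C(=O)NC2CCCCCC2)[C@@H](O)[C@H]1O` is not yet measured. It differs from compound 3 by cycloheptyl in place of 8-aminooctyl on an amide-type nitrogen. Among the compounds with values here, no measured step exchanges a chain for a ring, so this change has no direct precedent among the three compounds. What the measured steps do show is that changing the group carried on the amide nitrogen, whether by a longer chain in a 1.2-fold higher number from compound 1 to compound 2 (0.09 log units; within the scatter) or by an added amino group in a 1.4-fold higher number from compound 2 to compound 3 (0.14 log units; within the scatter), left this assay essentially unchanged. On that basis only a modest movement is expected, and compound 4 is estimated at 22 nM, with a range from 8 nM to 65 nM. The step this estimate implies, a 1.3-fold lower number from compound 3 to compound 4 (0.12 log units; within the scatter), is expected to stay within the scatter.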

Compound 4, inhibition constant: 22 nM
Compound 4: the middle estimate sits on the measured number at the digits printed, and the stated range covers the measured number.
By their numbers in this assay, from the lowest: compounds 1, 2, 4 and 3 (each within the scatter of the next).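

Within the data shown here, the amide nitrogen carries a ring here for the first time, and in this assay cycloheptyl reads the same as the open chains within the scatter: against 8-aminooctyl (a 1.3-fold lower number from compound 3 to compound 4 (0.12 log units; within the scatter)), against octyl (a 1.0-fold higher number from compound 2 to compound 4 (0.02 log units; within the scatter)) and against butyl (a 1.3-fold higher number from compound 1 to compound 4 (0.11 log units; within the scatter)). So this position has now accepted a closed seven-membered ring of carbon only as well as straight chains, and the swap from 8-aminooctyl also removes the hydrogen-bond donor and acceptor that group carries, with no step beyond the scatter. Nothing available explains why these different groups give such similar numbers.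

As far as these compounds go, all four groups on this nitrogen are saturated, and only compound 3 carries a polar end group, so it remains open whether the same flat picture would hold for an aromatic ring such as phenyl, a carboxylic acid at the end of the chain, or a ring bearing an amine. Smaller rings such as cyclopropyl, and replacement of the amide hydrogen itself, also remain open.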